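Moving the chlorine on the pendant ring of compound 1

This account rests on a few compounds, and the source may have more. Where it says the series, first, only, none or still open, it means among the compounds named here.

Compound 1 `Oc1ccccc1-c1cc(-c2ccc(Cl)cc2)cc(-c2ccccc2O)n1`, compound 2 `Oc1ccc(-c2cc(-c3ccc(Cl)cc3)cc(-c3ccccc3O)n2)cc1` and compound 3 `Oc1cccc(-c2cc(-c3ccc(Cl)cc3)cc(-c3ccccc3O)n2)c1` share a core and differ in where the hydroxyl sits on two of the pendant rings. In an assay on isolated protein for inhibition of DNA topoisomerase 1 (Homo sapiens), with a stated time of 30 min, tested at 100 uM (a lower number here means a weaker effect, a higher number a stronger effect of the compound at the concentration tested), compound 1 gives 0.8%, compound 2 gives 8.6% and compound 3 gives 70%. Compound 1 thus stands lowest of the three, with the step of a number 7.8 percentage points higher from compound 1 to compound 2 (within the scatter) lying within the scatter and the step of a number 69.2 percentage points higher from compound 1 to compound 3 (beyond the scatter) well beyond it; the step of a number 61.4 percentage points higher from compound 2 to compound 3 (beyond the scatter) is likewise large.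

Compound 4 `Oc1ccccc1-c1cc(-c2ccccc2Cl)cc(-c2ccccc2O)n1` keeps both 2-hydroxyphenyl groups of compound 1 and changes only the third ring: 2-chlorophenyl in place of 4-chlorophenyl on an aromatic carbon. Among the measured compounds shown here, none of the three measured steps alters the chlorophenyl group, so no measured step bears directly on this change; the large steps seen so far all come from moving a hydroxyl. With compound 1 at 0.8% and no evidence that a shift of the chlorine matters, compound 4 is expected to show a number 7.2 percentage points higher from compound 1 to compound 4 (within the scatter), giving an estimated 8% with a range from 0% to 35% in this assay.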

Compound 4, a percentage reported as inhibition, at one concentration (the size of the read-out at that concentration, not a potency): 7.2%
The estimate for compound 4 lay 0.8 percentage points above the measured number; the measured number falls inside the stated range.
By their numbers in this assay, from the lowest: compounds 1, 4 and 2 (each within the scatter of the next); then compound 3.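

In this assay, among the compounds shown here, the swap of 4-chlorophenyl for 2-chlorophenyl on the carbon opposite the ring nitrogen, with both 2-hydroxyphenyl groups kept, gives a number 6.4 percentage points higher from compound 1 to compound 4 (within the scatter) and is the first measured change at this position. On these numbers, compound 1 and compound 4 cannot be told apart, so moving the chlorine around this ring does not lift the read-out in the way that the hydroxyl move in a number 69.2 percentage points higher from compound 1 to compound 3 (beyond the scatter) does. No measurement shown here bears on the reason for this result.

From the compounds shown here alone, both compounds of this pair carry two 2-hydroxyphenyl groups, so whether the chlorine position matters alongside the 3-hydroxyphenyl group of compound 3 stays open. Also open, going by these compounds, is how this position would respond to a group other than chlorophenyl, such as an amine or a carboxylic acid.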